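Nitro to hydrogen on compound 1

The compounds below may be only part of what the source reports. "The series", "measured", "known", "first", "only" and "open" are said of these compounds alone.

In a physicochemical assay, with a stated time of 6 min (on this read-out higher numbers stand for weaker inhibition and lower numbers for stronger inhibition), compound 1 (`O=C(Nc1ccc([N+](=O)[O-])cc1)Nc1nc(-c2cc3cc(Br)ccc3o2)cs1`) gives > 200000 nM as a limit and not a number (the limit of > 200000 nM in this assay, at which 1 of the 3 values shown sits). Compound 4 (`O=C(Nc1ccccc1)Nc1nc(-c2cc3cc(Br)ccc3o2)cs1`) carries hydrogen in place of nitro on an aromatic carbon. In this assay compound 2 (`O=C(Nc1ccc([N+](=O)[O-])cc1)Nc1nc(-c2cc3ccccc3o2)cs1`) gives 19300 nM and compound 3 (`Cc1ccc(NC(=O)Nc2nc(-c3cc4ccccc4o3)cs2)cc1`) gives 500 nM on the same scale. Going by the values given here, two measured steps bear on the change: methyl in place of nitro gave a 39-fold lower number from compound 2 to compound 3 (1.59 log units; beyond the scatter) without bromo present, and hydrogen in place of bromo gave an at least 10-fold lower number from compound 1 to compound 2 (1.01 log units; beyond the scatter) with nitro present. Neither step puts hydrogen in place of nitro. A large step towards a lower number, meaning stronger inhibition, is expected, estimated as an at least 40-fold lower number from compound 1 to compound 4 (1.60 log units; beyond the scatter) in size. For compound 4 the estimated value is 5000 nM with an expected range of 800 nM to 40000 nM for now.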

Compound 4, half-maximal inhibitory concentration: > 200000 nM
Compound 4 ended at the assay's limit; the forecaster's own chance of this, stated with the estimate: 10%; middle value at least 40-fold (1.60 log units) from the limit.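

In this assay, going by these compounds alone, compound 1 and compound 4 both stand at the assay's limit, so no step between them can be read: the limit of > 200000 nM in this assay, at which 2 of the 4 values shown sit.

The compounds shown leave open whether hydrogen in place of nitro changes inhibition at all when bromo is present.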